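The compounds below may be only part of what the source reports. "The series", "measured", "known", "first", "only" and "open" are said of these compounds alone.

Working notes on the series. Of the compounds shown here, three have been measured so far in a functional assay on HEK293 cells for agonist activity at Vasopressin V2 receptor (Homo sapiens), read by a luciferase reporter and cAMP accumulation; on this read-out higher numbers stand for an effect only at larger amounts of compound and lower numbers for an effect already at smaller amounts. Compound 1 `Cc1cc(C(=O)N2CCCCc3ccccc32)ccc1CNC(=O)Nc1ccccc1` gives 130 nM, compound 2 `Cc1cc(C(=O)N2CCCCc3ccccc32)ccc1CNC(=O)NCC(=O)N(C)C` gives 58 nM, and compound 3 `Cc1cc(C(=O)N2CCCCc3ccccc32)ccc1CNC(=O)NCC(=O)N1CCCC1` gives 100 nM. On these numbers compound 3 stands second highest of the three; its step from compound 1 is a 1.3-fold lower number from compound 1 to compound 3 (0.11 log units; within the scatter) and that from compound 2 is a 1.7-fold higher number from compound 2 to compound 3 (0.24 log units; within the scatter), both within the scatter, so only a 2.2-fold lower number from compound 1 to compound 2 (0.35 log units; beyond the scatter) separates any pair.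

Compound 4 `Cc1cc(C(=O)N2CCCCc3ccccc32)ccc1CNC(=O)N1CCC[C@H]1C(=S)N(C)C` is not yet measured. Compared with compound 3 the change is a group of 10 heavy atoms (7 carbon, 2 nitrogen, 1 sulfur; one five-membered non-aromatic ring with 1 hetero atom) in place of a group of 9 heavy atoms (6 carbon, 2 nitrogen, 1 oxygen; one five-membered non-aromatic ring with 1 hetero atom), on a carbonyl carbon; the entering group carries sulfur where the leaving group carried oxygen, has a defined stereocentre and brings no hydrogen-bond donor.

Only a 1.7-fold higher number from compound 2 to compound 3 (0.24 log units; within the scatter) bears directly on this step, exchanging pyrrolidin-1-yl for dimethylamino on a carbonyl carbon, and it stayed within the scatter; a 2.2-fold lower number from compound 1 to compound 2 (0.35 log units; beyond the scatter) and a 1.3-fold lower number from compound 1 to compound 3 (0.11 log units; within the scatter) show that varying the group on the amide-type nitrogen has moved this assay only modestly. None of them covers a sulfur for oxygen exchange or the loss of the donor, so the expected step of no change at the digits printed from compound 3 to compound 4 (within the scatter) is none beyond the scatter, with a wide range. Compound 4 is therefore estimated at 100 nM, between 35 nM and 300 nM.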

Compound 4, half-maximal effective concentration: 3.2 nM
Compound 4: the middle estimate sits 31-fold (1.49 log units) above what was measured, outside the stated range (below it).
By their numbers in this assay, from the lowest: compound 4; then compounds 2, 3 and 1 (each within the scatter of the next, the first and the last beyond it).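

In this assay the group on the carbonyl carbon proves able to move the read-out far more than the earlier exchanges showed, with a 31-fold lower number from compound 3 to compound 4 (1.49 log units; beyond the scatter) and an 18-fold lower number from compound 2 to compound 4 (1.26 log units; beyond the scatter) and a 41-fold lower number from compound 1 to compound 4 (1.61 log units; beyond the scatter) all large, and compound 4 alone lies beyond the scatter of every other compound. The step combines several differences at once, namely sulfur where oxygen stood, a defined stereocentre and the loss of the hydrogen-bond donor, so no single one of them can be credited with it. Nothing available here accounts for the size of this step.

It remains open which of these differences carries the step, since the oxygen analogue of compound 4 with a carbonyl and the opposite stereoisomer are not among the compounds shown. Also open, on these data alone, is whether a six-membered piperidine ring in place of the five-membered ring, or a carboxylic acid on that ring, would hold the low number.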